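The compounds below may be only part of what the source reports. "The series", "measured", "known", "first", "only" and "open" are said of these compounds alone.

Compound 1 `CO[C@@H]1CC=C2NN(c3cc(Cl)cc(Cl)c3)C(=O)C[C@]2(C)O1` is the simplest of the three measured compounds; in a functional assay on SK-BR-3 cells (Homo sapiens) for inhibition, read by sulforhodamine B assay, with a stated time of 48 h (on this read-out lower numbers stand for stronger inhibition and higher numbers for weaker inhibition), compound 1 gives 18800 nM. Compound 2 `CO[C@@H]1CC=C2NN(c3cc(Cl)cc(Cl)c3)C(=O)C[C@]2(c2ccncc2)O1` differs from it by pyridin-4-yl in place of methyl on a saturated ring carbon, and in this assay compound 2 gives 5500 nM, so the change made a step of a 3.4-fold lower number from compound 1 to compound 2 (0.53 log units; beyond the scatter). Compound 3 `COc1cc(OC)cc(N2NC3=CC[C@@H](OC)O[C@@]3(C)CC2=O)c1` is built on another core; how this core differs from that of compound 1 is not broken down here. In this assay compound 3 gives 5700 nM, a number within the scatter of that of compound 2. Compound 4 `COc1cc(OC)cc(N2NC3=CC[C@@H](OC)O[C@@]3(c3ccncc3)CC2=O)c1` has not yet been measured; it differs from compound 3 by pyridin-4-yl in place of methyl on a saturated ring carbon. This is the same kind of change as that from compound 1 to compound 2, though the place reads differently: for compound 1 it is given as next to the ring oxygen and next to the ring atom that bears a fused ring, for compound 3 as two ring bonds from the ring nitrogen and three ring bonds from the ring atom that bears a large group. A step of about a 3.2-fold lower number from compound 3 to compound 4 (0.50 log units; beyond the scatter) is expected for compound 4, resting on the step of a 3.4-fold lower number from compound 1 to compound 2 (0.53 log units; beyond the scatter) seen on the other core. Compound 4 is therefore estimated at 1800 nM, expected to fall between 700 nM and 4500 nM.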

Compound 4, half-maximal inhibitory concentration: 210 nM
For compound 4 the middle estimate is 8.6-fold (0.93 log units) above the measured one, outside the stated range (below it).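

In this assay, putting pyridin-4-yl in place of methyl gives a 27-fold lower number from compound 3 to compound 4 (1.43 log units; beyond the scatter), so the number falls on both cores, but the size of the step does not carry over from one core to the other: the same change on two cores in this assay, a 3.4-fold lower number (0.53 log units; beyond the scatter) from compound 1 to compound 2 and a 27-fold lower number (1.43 log units; beyond the scatter) from compound 3 to compound 4, 7.9-fold (0.90 log units) apart, beyond the scatter of two such steps For these two pairs, then, the direction of the change is shared, while the step seen on the core of compound 1 does not give the size of the step on the core of compound 3. Among these compounds, with only two pairs, the data do not show which part of the two cores goes with the larger step, or what size the step would take on any further core.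

The compounds shown leave open whether phenyl or pyridin-3-yl on the same saturated ring carbon would also give steps that differ in size between the two cores. They also leave open how the numbers would move if an amine or a hydroxyl group took the place of the methoxy group shared by all four compounds.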